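The compounds below may be only part of what the source reports. "The series", "measured", "known", "first", "only" and "open" are said of these compounds alone.

The series rests on compound 1, `O=C(O)/C=C/C(=O)c1ccccc1`, a phenyl ketone carrying an unsaturated acid chain. In a functional assay on LS174T cells (Homo sapiens) for inhibition, read by MTT assay, with a stated time of 72 h (a higher number here means a weaker inhibitor, a lower number a stronger inhibitor), compound 1 gives 45500 nM, the highest of the two numbers recorded so far. Within the data shown here, its only measured companion is compound 2, `CCCCCCCCCCCCc1ccc(C(=O)/C=C/C(=O)O)cc1`, which in this assay gives 7850 nM, a number that stands well below that of compound 1 and beyond the usual scatter of the measurement. Among the measured compounds shown here, no step between two measured compounds that differ in a single place has been recorded, so any expectation for a new compound must draw on these two values alone.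

The next compound, compound 3, `CCc1ccc(C(=O)/C=C/C(=O)O)cc1`, has not yet been measured. It differs from compound 1 by ethyl in place of hydrogen on an aromatic carbon, the ethyl sitting on the six-membered aromatic ring of carbon only, para to a group of 7 heavy atoms. The account expects the number for compound 3 to move downward from compound 1, probably by a modest step, and the estimated step of a 1.6-fold lower number from compound 1 to compound 3 (0.21 log units; within the scatter) may fall only just beyond the scatter. Compound 3 is therefore estimated at 28000 nM, within a range from 12000 nM to 60000 nM.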

Compound 3, half-maximal inhibitory concentration: 21000 nM
Compound 3: the middle estimate sits 1.3-fold (0.12 log units) above what was measured; low and high end bracket the measured number.
By their numbers in this assay, from the lowest: compound 2; then compound 3; then compound 1.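

In this assay, among these compounds, ethyl in place of hydrogen on an aromatic carbon, para to a group of 7 heavy atoms, gives a 2.2-fold lower number from compound 1 to compound 3 (0.34 log units; beyond the scatter), the first measured change at a single place. The step is modest, yet it shows that a group of only 2 heavy atoms in this place already lowers the number beyond the scatter, which the two earlier values alone could not show. Nothing measured here explains why the number moves.

Compound 2 carries a longer chain in the same place and stands at 7850 nM, while compound 3 stands at 21000 nM, so the compounds shown leave open how the number runs for a propyl, butyl or hexyl chain in that place. They also leave open whether a methoxy group, a chlorine atom or an amine there would lower the number as ethyl does, and whether an ester or an amide could stand in place of the carboxylic acid of the shared core.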